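Amine Size on a Longer Chain: Compound 4 Projected

This account rests on a few compounds, and the source may have more. Where it says the series, first, only, none or still open, it means among the compounds named here.

Compound 1 `CN(C)CCn1c(N)c(-c2nc3cc(Cl)ccc3[nH]2)c2nc(C#N)c(C#N)nc21` gives 11800 nM in a functional assay on Raji cells (Homo sapiens) for antiproliferative activity, read by MTT assay, with a stated time of 48 h; a higher number here means a weaker inhibitor, a lower number a stronger inhibitor. Compound 2 `CCN(CC)CCn1c(N)c(-c2nc3cc(Cl)ccc3[nH]2)c2nc(C#N)c(C#N)nc21` carries diethylamino in place of dimethylamino on a saturated chain carbon, two bonds along the chain from an aromatic nitrogen and gives 31500 nM in this assay, a step of a 2.7-fold higher number from compound 1 to compound 2 (0.43 log units; beyond the scatter). Compound 3 `CN(C)CCCCn1c(N)c(-c2nc3cc(Cl)ccc3[nH]2)c2nc(C#N)c(C#N)nc21` differs from compound 1 by 2-(dimethylamino)ethyl in place of dimethylamino on a saturated chain carbon, two bonds along the chain from an aromatic nitrogen, and compound 3 gives 950 nM in this assay, the step being a 12-fold lower number from compound 1 to compound 3 (1.09 log units; beyond the scatter); the step of a 33-fold lower number from compound 2 to compound 3 (1.52 log units; beyond the scatter) is larger still. Compound 4 `CCN(CC)CCCCn1c(N)c(-c2nc3cc(Cl)ccc3[nH]2)c2nc(C#N)c(C#N)nc21` is not yet measured. It carries diethylamino in place of dimethylamino on a saturated chain carbon, four bonds along the chain from an aromatic nitrogen, the same kind of change as that from compound 1 to compound 2, though here the place is four bonds along the chain from an aromatic nitrogen rather than two. Because that change gave a 2.7-fold higher number from compound 1 to compound 2 (0.43 log units; beyond the scatter), a step of similar size is expected. Compound 4 is expected to show a 2.6-fold higher number from compound 3 to compound 4 (0.42 log units; beyond the scatter) in this assay. Compound 4 is therefore estimated at 2500 nM, with a range from 900 nM to 7000 nM.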

Compound 4, half-maximal inhibitory concentration: 720 nM
Estimate against measurement, compound 4: 3.5-fold (0.54 log units) above; the measured number lies below the stated range.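

In this assay, diethylamino in place of dimethylamino four bonds along the chain from an aromatic nitrogen gives a 1.3-fold lower number from compound 3 to compound 4 (0.12 log units; within the scatter), so the change did not carry over with the size it had two bonds along the chain: the same change on two cores in this assay, a 2.7-fold higher number (0.43 log units; beyond the scatter) from compound 1 to compound 2 and a 1.3-fold lower number (0.12 log units; within the scatter) from compound 3 to compound 4, 3.5-fold (0.55 log units) apart, beyond the scatter of two such steps. Extending the chain while keeping diethylamino gives a 44-fold lower number from compound 2 to compound 4 (1.64 log units; beyond the scatter), and changing both chain and amine gives a 16-fold lower number from compound 1 to compound 4 (1.21 log units; beyond the scatter). This shows that the effect of the amine change differs between these two cores, but with one pair per core in one assay, it does not show how the change would behave on any other core, nor why the steps differ.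

The compounds shown leave open what a cyclic amine such as pyrrolidine or morpholine, or a still longer chain, would give in this assay.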